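Removing One Fluorine From the Core of Compound 1

The source may hold more compounds than are shown below. What is called first, only, known or untested is meant among the compounds shown, and "the series" means these compounds.

Compound 1 `CCC(Nc1nnc(-c2ccc(OC)cc2)o1)[C@H]1CC[C@@H](c2ccnc3c(F)cc(F)cc32)CC1`: 36 nM
Compound 2 `CCC(c1nc2ccc(Cl)cc2[nH]1)[C@H]1CC[C@@H](c2ccnc3ccc(F)cc32)CC1`: 3 nM
Compound 3 `COc1ccc(-c2nnc(N[C@H](C)[C@H]3CC[C@@H](c4ccnc5ccc(F)cc54)CC3)o2)cc1`: 14 nM

All three were tested in an assay on tissue (M109 cells) for inhibition of Indoleamine 2,3-dioxygenase 1 (Mus musculus), read by fluorescence, with a stated time of 18 h; on this read-out higher numbers stand for weaker inhibition and lower numbers for stronger inhibition. Compound 1 stands at the highest of the three numbers, that is the weakest inhibition seen; its gaps to compound 3 and to compound 2 both lie beyond the scatter. Compound 4 `CCC(Nc1nnc(-c2ccc(OC)cc2)o1)[C@H]1CC[C@@H](c2ccnc3ccc(F)cc32)CC1` differs from compound 1 in one place: hydrogen in place of fluoro on an aromatic carbon. Among the measured compounds shown here, no pair of measured compounds isolates exactly this change, so the size of the step is uncertain. Still, compound 2 (3 nM) and compound 3 (14 nM) carry the same core as compound 4 and both sit below compound 1, which supports expecting movement toward stronger inhibition. In this assay the expected step is a 2.0-fold lower number from compound 1 to compound 4 (0.30 log units; within the scatter). Compound 4 is therefore estimated at 18 nM, within 8 nM to 45 nM.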

Compound 4, half-maximal inhibitory concentration: 31 nM
Estimate against measurement, compound 4: 1.7-fold (0.24 log units) below; measured number inside the range.
By their numbers in this assay, from the lowest: compound 2; then compound 3; then compounds 4 and 1 (each within the scatter of the next).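

In this assay, replacing the fluoro group ortho to a fused ring with hydrogen gives a 1.2-fold lower number from compound 1 to compound 4 (0.06 log units; within the scatter). At this position of compound 1, the two substituents therefore cannot be told apart on this read-out, and the inhibition does not depend on this fluoro group. Nothing available explains this result. The compounds shown leave open whether a nitrile or an amine at this position would shift the number. They also leave open whether the same exchange would give a similar step with the side chain of compound 2.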